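Chloro added to the benzoyl ring of compound 3

The source may hold more compounds than are shown below. What is called first, only, known or untested is meant among the compounds shown, and "the series" means these compounds.

Measured compounds:
compound 1 `O=C(Nc1ccccc1O)C1CCc2ccccc2N1` gives 3990 nM in a functional assay on ACHN cells (Homo sapiens) for cytotoxicity, read by sulforhodamine B assay, with a stated time of 72 h; on this read-out higher numbers stand for weaker inhibition of growth and lower numbers for stronger inhibition of growth
compound 2 `O=C(Nc1ccccc1C(F)(F)F)C1CCc2ccccc2N1C(=O)c1ccccc1Cl` gives 3900 nM in this assay
compound 3 `O=C(Nc1ccccc1O)C1CCc2ccccc2N1C(=O)c1ccccc1` gives 4260 nM in this assay

Compound 3 shows the highest of the three numbers, yet compound 1 and compound 2 both lie within the scatter of it, so no order among the three can be stated. Going by the values given here, the one step with a single change, a 1.1-fold higher number from compound 1 to compound 3 (0.03 log units; within the scatter), stays within the scatter.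

Compound 4 `O=C(Nc1ccccc1O)C1CCc2ccccc2N1C(=O)c1ccccc1Cl` is not yet measured. It differs from compound 3 by chloro in place of hydrogen on an aromatic carbon. Among the compounds with values here, no measured step covers this change on its own; compound 2 carries the same chloro but also another difference, and its value sits within the scatter of compound 3. For compound 4 the step of a 1.1-fold lower number from compound 3 to compound 4 (0.03 log units; within the scatter) is therefore expected to stay within the scatter. Compound 4 is estimated at 4000 nM, between 2000 nM and 8000 nM.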

Compound 4, concentration for 50% growth inhibition: 44200 nM
Beside the measured number, compound 4's estimate is 11-fold (1.04 log units) below it, outside the stated range (above it).
By their numbers in this assay, from the lowest: compounds 2, 1 and 3 (each within the scatter of the next); then compound 4.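

In this assay, going by these compounds alone, chloro on the benzoyl ring is the first change to weaken growth inhibition beyond the scatter, with a 10-fold higher number from compound 3 to compound 4 (1.02 log units; beyond the scatter). The effect depends on the combination of groups: with this chloro present, hydroxy in place of trifluoromethyl gives an 11-fold higher number from compound 2 to compound 4 (1.05 log units; beyond the scatter), and (2-chlorophenyl)carbonyl on the ring nitrogen gives an 11-fold higher number from compound 1 to compound 4 (1.04 log units; beyond the scatter), although unsubstituted benzoyl there stayed within the scatter. Nothing available explains this drop.

Going by these compounds, it remains open whether a methoxy group or an amine on the same aromatic carbon would act like chloro. Also open, on these data alone, is how hydroxy and trifluoromethyl compare on an unsubstituted benzoyl.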